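Acetylation of the ring nitrogen: compound 3 to compound 4

A few compounds are considered here, and "the series" means these few. Any claim that something is new, unique, unknown or untested is made for them only; others in the source may bear on it.

Going by the values given here, compound 3 `Cc1ccc(S(=O)(=O)N2C=CNC(=O)[C@H]2CC(=O)NC2CCNc3ccccc32)cc1` gives 21.6 nM in an in vitro functional assay on cells for antagonist activity at B1 bradykinin receptor (Homo sapiens), read by luminescence and calcium flux, with a stated time of 2 h (a higher number here means a weaker inhibitor, a lower number a stronger inhibitor), the lowest of the three numbers measured so far. Compound 2 `Cc1ccc(S(=O)(=O)N2C=CNC(=O)[C@H]2CC(=O)N[C@@H]2CCc3ccccc32)cc1` gives 94.7 nM, and compound 1 `Cc1ccc(S(=O)(=O)N2C=CNC(=O)[C@H]2CC(=O)N[C@H](C)c2ccccc2)cc1` gives 836 nM. The measured steps all change the group on the amide-type nitrogen: an 8.8-fold lower number from compound 1 to compound 2 (0.95 log units; beyond the scatter), a 4.4-fold lower number from compound 2 to compound 3 (0.64 log units; beyond the scatter) and a 39-fold lower number from compound 1 to compound 3 (1.59 log units; beyond the scatter).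

Compound 4 `CC(=O)N1CCC(NC(=O)C[C@@H]2C(=O)NC=CN2S(=O)(=O)c2ccc(C)cc2)c2ccccc21` differs from compound 3 by acetyl in place of hydrogen on a nitrogen on an aromatic ring in a ring. None of the three measured steps bears on this change: each swaps the whole group on the amide-type nitrogen, and none alters a substituent on the nitrogen in the six-membered non-aromatic ring. Among the compounds with values here, there is therefore no precedent for the direction or size of the step in this assay, and the expectation rests on the change being small relative to those already measured. The working estimate is a step of a 2.1-fold higher number from compound 3 to compound 4 (0.32 log units; beyond the scatter), which may fall within the scatter, with a somewhat higher number held slightly more likely than a lower one. Compound 4 is estimated at 45 nM, within a range of 12 nM to 170 nM.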

Compound 4, half-maximal inhibitory concentration: 72.2 nM
For compound 4 the middle estimate is 1.6-fold (0.21 log units) below the measured one; the measured number falls inside the stated range.
By their numbers in this assay, from the lowest: compound 3; then compounds 4 and 2 (each within the scatter of the next); then compound 1.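

In this assay, going by these compounds alone, this is the first reading of a change on the nitrogen of the six-membered non-aromatic ring itself, rather than a swap of the whole group on the amide-type nitrogen: acetyl in place of hydrogen gives a 3.3-fold higher number from compound 3 to compound 4 (0.52 log units; beyond the scatter), a move towards a weaker inhibitor that lies beyond the scatter. Compound 4 still gives 72.2 nM, so the hydrogen on this nitrogen is not required for inhibition in the tens of the measured range, and the position accepts acetyl at a modest cost. Nothing on hand explains the size or direction of this step.

On these data alone, whether the cost belongs to acetyl in particular or to any group on this nitrogen stays open; a methyl or a methanesulfonyl group at the same place would separate the two. Also open, as far as these compounds go, is how the step would read for a single configuration at the ring atom that bears the large group.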